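Adding a methoxy to compound 2: expected outcome

A few compounds are considered here, and "the series" means these few. Any claim that something is new, unique, unknown or untested is made for them only; others in the source may bear on it.

Compound 1 `COc1cc(CC(COCc2ccccc2)COCc2ccccc2)nc(OC)n1` gives 300 nM in a functional assay on MCF7 cells (Homo sapiens) for antiproliferative activity, read by MTT assay, with a stated time of 72 h; a lower number here means a stronger inhibitor, a higher number a weaker inhibitor. Compound 2 `COc1cc(CC(O)COCc2ccccc2)nc(OC)n1` sits at the limit of > 100000 nM in this assay, at which 1 of the 2 values shown sits. In this assay compound 2 gives > 100000 nM, which is a limit of the assay and not a number. Among the compounds with values here, the only measured step is an at least 330-fold higher number from compound 1 to compound 2 (2.52 log units; beyond the scatter). Compound 3 `COc1nc(CC(O)COCc2ccccc2)c(OC)c(OC)n1` differs from compound 2 by methoxy in place of hydrogen on an aromatic carbon. Within the data shown here, no measured step bears on a methoxy entering the aromatic ring, so nothing indicates a change beyond the scatter. The step of a number no higher from compound 2 to compound 3 (the limit leaves the size open) is therefore expected to be small. Compound 3 is expected at 100000 nM, between 20000 nM and 300000 nM, most likely reported again only as a limit.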

Compound 3, half-maximal inhibitory concentration: > 100000 nM
Compound 3: only a limit was reported (the forecaster's own chance of this, stated with the estimate: 70%); the middle value lies on the limit itself.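

Within the data shown here, compound 2 and compound 3 both stand only as limits in this assay, so no step between them can be read. From the compounds shown here alone, whether methoxy in place of hydrogen on the aromatic carbon changes the activity at all remains open.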